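Amide nitrogen substituents and low-pH solubility in the series

The source may hold more compounds than are shown below. What is called first, only, known or untested is meant among the compounds shown, and "the series" means these compounds.

Three measured compounds share one core and differ only at the carbonyl substituent. Compound 1 `COCCOC(=O)c1cc(N)c(Nc2ccc(C#N)cc2)cc1Oc1c(C)cc(/C=C/C#N)cc1C` carries the 2-methoxyethoxy ester and in a physicochemical assay for solubility, read by HPLC, with a stated time of 4 h, at pH 2 (on this read-out higher numbers stand for higher solubility and lower numbers for lower solubility), compound 1 gives 1.64 ug/mL. Compound 2 `CCNC(=O)c1cc(N)c(Nc2ccc(C#N)cc2)cc1Oc1c(C)cc(/C=C/C#N)cc1C` carries the ethylamide and in this assay compound 2 gives 69.4 ug/mL. Compound 3 `Cc1cc(/C=C/C#N)cc(C)c1Oc1cc(Nc2ccc(C#N)cc2)c(N)cc1C(=O)NN` carries the hydrazide and in this assay compound 3 gives 89.6 ug/mL. Compound 3 holds the highest of the three numbers, but its separation from compound 2 is within the scatter, so no order between those two can be claimed; only compound 1 sits clearly apart. The steps of a 42-fold higher number from compound 1 to compound 2 (1.63 log units; beyond the scatter) and a 55-fold higher number from compound 1 to compound 3 (1.74 log units; beyond the scatter) are both large, whereas a 1.3-fold higher number from compound 2 to compound 3 (0.11 log units; within the scatter) is within the scatter.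

Compound 4 `Cc1cc(/C=C/C#N)cc(C)c1Oc1cc(Nc2ccc(C#N)cc2)c(N)cc1C(=O)NCCCO` is the next member: 3-hydroxypropyl in place of amino on an amide-type nitrogen. Among the compounds with values here, the step that bears on this change is the one from compound 2 to compound 3, in which the group on the amide-type nitrogen was exchanged without any shift beyond the scatter; the two large steps concern the ester and do not apply here, since compound 4 keeps the amide. A step of no more than the scatter in this assay is therefore expected, in either direction, a 1.2-fold lower number from compound 3 to compound 4 (0.08 log units; within the scatter). For compound 4 the expected value is 75 ug/mL, with a range from 30 ug/mL to 180 ug/mL.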

Compound 4, solubility: 19.9 ug/mL
Beside the measured number, compound 4's estimate is 3.8-fold (0.58 log units) above it; measured number below the stated range.
By their numbers in this assay, from the lowest: compound 1; then compound 4; then compounds 2 and 3 (each within the scatter of the next).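

The group on the amide-type nitrogen does matter in this assay: the earlier exchange at this nitrogen gave only a 1.3-fold higher number from compound 2 to compound 3 (0.11 log units; within the scatter), but 3-hydroxypropyl in place of amino gives a 4.5-fold lower number from compound 3 to compound 4 (0.65 log units; beyond the scatter), and hydroxymethyl in place of hydrogen on the saturated chain gives a 3.5-fold lower number from compound 2 to compound 4 (0.54 log units; beyond the scatter), so the two earlier amide-type compounds no longer mark the range for this position. The ester remains clearly apart, with (3-hydroxypropyl)amino in place of 2-methoxyethoxy on the carbonyl carbon giving a 12-fold higher number from compound 1 to compound 4 (1.08 log units; beyond the scatter), so all three amide-type compounds stand beyond the scatter from compound 1, though the size of that step now depends on the group on the nitrogen. No measured property at hand bears on this result.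

The compounds shown do not separate the length of the chain from its terminal hydroxyl, since the chain and the hydroxyl enter together in compound 4 when it is set against compound 3. A 2-hydroxyethyl, a plain propyl, a 3-methoxypropyl or a 3-aminopropyl group on the same nitrogen would tell these apart.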